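From Selenium to Tellurium in a Shared Core

A few compounds are considered here, and "the series" means these few. Any claim that something is new, unique, unknown or untested is made for them only; others in the source may bear on it.

Measured compounds:
- Compound 1, `COc1ccc(N(CC(=O)NCCC[Se]c2ccccc2)C(=O)c2ccccc2)cc1`. In an ADME assay on cells (Fibroblast, Homo sapiens) for cytotoxicity, read by MTT assay, with a stated time of 24 h (a lower number here means a stronger inhibitor, a higher number a weaker inhibitor), compound 1 gives >= 100000 nM, which is a limit of the assay rather than a number.
- Compound 2, `COc1ccc(N(CC(=O)NCCC[Se]c2ccccc2)C(=O)/C=C/c2ccccc2)cc1`. In this assay compound 2 gives >= 100000 nM, again a limit.
- Compound 3, `COc1ccc(N(CC(=O)NCCC[Se]c2ccccc2)C(=O)C#Cc2ccccc2)cc1`. In this assay compound 3 gives >= 100000 nM, also a limit.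

Compound 1 therefore has no exact position on the scale; all that is known is that it sits at the limit of >= 100000 nM in this assay, at which 3 of the 3 values shown sit, together with the other two. The steps among the measured compounds, which change the group on the carbonyl carbon, are a step that the two limits leave unreadable from compound 1 to compound 2, a step that the two limits leave unreadable from compound 1 to compound 3 and a step that the two limits leave unreadable from compound 2 to compound 3.

Compound 4, `COc1ccc(N(CC(=O)NCCC[Te]c2ccccc2)C(=O)c2ccccc2)cc1`, differs from compound 1 by a group of 7 heavy atoms (6 carbon, 1 tellurium; one six-membered aromatic ring of carbon only) in place of a group of 7 heavy atoms (6 carbon, 1 selenium; one six-membered aromatic ring of carbon only), on a saturated chain carbon, three bonds along the chain from an amide-type nitrogen. For the measured compounds named here, none of the measured steps touches this part of the molecule, and none of them is readable, so they give no direction for this change. The expectation is that compound 4 will behave like compound 1 and most likely also reach only the limit, with an estimated step of a number no higher from compound 1 to compound 4 (the limit leaves the size open) in this assay. Compound 4 is thus estimated at 100000 nM, within a range from 30000 nM to 300000 nM.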

Compound 4, half-maximal inhibitory concentration: 7500 nM
The estimate for compound 4 lay 13-fold (1.12 log units) above the measured number, and the stated range ends above it.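

In this assay, the tellurium-bearing group in place of the selenium-bearing group, on a saturated chain carbon, three bonds along the chain from an amide-type nitrogen, gives an at least 13-fold lower number from compound 1 to compound 4 (1.12 log units; beyond the scatter). The value for compound 1 is a limit, so this step has a known minimum but no exact size. Changing this one atom is the only readable change here, as the steps among compound 1, compound 2 and compound 3 cannot be read, and compound 4 alone has an exact number: the limit of >= 100000 nM in this assay, at which 3 of the 4 values shown sit.

On these data alone, whether tellurium would lower the number in the same way with the 2-phenylethenyl or 2-phenylethynyl group on the carbonyl carbon stays open. So does the effect of sulfur in place of selenium, or of a longer chain carrying the tellurium.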